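This account rests on a few compounds, and the source may have more. Where it says the series, first, only, none or still open, it means among the compounds named here.

Compound 1, `CC(C)(C)c1cc(/C=C/C(=O)NCC2CCN(Cc3ccccc3)CC2)cc(C(C)(C)C)c1O`, gives 48400 nM in an assay on isolated protein for inhibition of Amine oxidase [flavin-containing] A (Homo sapiens), read by fluorescence, with stated times of 15 min and 20 min; on this read-out higher numbers stand for weaker inhibition and lower numbers for stronger inhibition.
Compound 2, `Cc1ccc(CN2CCC(CCNC(=O)/C=C/c3cc(C(C)(C)C)c(O)c(C(C)(C)C)c3)CC2)cc1`, gives 70100 nM in this assay.

Going by the values given here, only two compounds have been measured so far, and they sit very close together: in this assay compound 2 gives the higher of the two numbers, but the gap to compound 1 is within the usual scatter of repeated measurements, so the two cannot be told apart on the numbers alone. Among the compounds with values here, neither pair of measured compounds differs in just one place, so no single structural step has yet been tied to a change in the read-out.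

Compound 3, `CC(C)(C)c1cc(/C=C/C(=O)NCCC2CCN(Cc3ccc(F)c(F)c3)CC2)cc(C(C)(C)C)c1O`, has not been measured. It differs from compound 2 as follows: 3,4-difluorophenyl in place of 4-methylphenyl on a saturated chain carbon bound to an amine nitrogen in a ring. Both of these groups are aromatic rings without hydrogen-bond donors or acceptors and without charge, and the swap takes place at the outer end of the molecule, far from the shared core. Nothing in the measured data says how such a swap moves the read-out.

The expectation for compound 3 is therefore a step of roughly a 1.2-fold lower number from compound 2 to compound 3 (0.07 log units; within the scatter), that is, no change beyond the scatter. Compound 3 is expected to give about 60000 nM, somewhere between 25000 nM and 150000 nM.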

Compound 3, half-maximal inhibitory concentration: 64500 nM
Beside the measured number, compound 3's estimate is 1.1-fold (0.03 log units) below it; measured number inside the range.
By their numbers in this assay, from the lowest: compounds 1, 3 and 2 (each within the scatter of the next).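

Going by these compounds alone, this is the first step that ties a single structural change to the read-out. In this assay, putting 3,4-difluorophenyl in place of 4-methylphenyl on a saturated chain carbon bound to an amine nitrogen in a ring gives a 1.1-fold lower number from compound 2 to compound 3 (0.04 log units; within the scatter) and so stays within the scatter: at this place, the two groups cannot be told apart on the numbers, even though one carries carbon alone and the other brings in fluorine. No measurement shown here explains this result.

From the compounds shown here alone, both groups are six-membered aromatic rings of carbon with no hydrogen-bond donors or acceptors and no net charge, so it remains open whether a group of a different kind at this place, such as a carboxylic acid or an amine, would move the number beyond the scatter. Going by these compounds, compound 1 differs from compound 2 and from compound 3 in more than one place, so what the length of the chain alone does to the read-out also remains open.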